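The source may hold more compounds than are shown below. What is called first, only, known or untested is meant among the compounds shown, and "the series" means these compounds.

Measured compounds in a functional assay on PC-3 cells (Homo sapiens) for inhibition; a higher number here means a weaker inhibitor, a lower number a stronger inhibitor:
- compound 1, `Cc1c(C(=O)N/N=C\c2ccccc2F)oc2cccc(O)c12`: >= 40000 nM
- compound 2, `Cc1c(C(=O)N/N=C\c2cccc(F)c2)oc2cccc(O)c12`: >= 40000 nM
- compound 3, `COc1cccc(/C=N\NC(=O)c2oc3cccc(O)c3c2C)c1`: >= 40000 nM

All three values are limits of this assay, not numbers. Compound 1 sits at a limit, as do the other two; the limit of >= 40000 nM in this assay, at which 3 of the 3 values shown sit, states this. Consequently none of the steps between them is readable: a step that the two limits leave unreadable from compound 1 to compound 2, a step that the two limits leave unreadable from compound 1 to compound 3, a step that the two limits leave unreadable from compound 2 to compound 3.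

Compound 4, `Cc1c(C(=O)N/N=C\c2ccc(Br)cc2O)oc2cccc(O)c12`, differs from compound 1 as follows: 4-bromo-2-hydroxyphenyl in place of 2-fluorophenyl on a carbon with a double bond to nitrogen. Among the measured compounds shown here, no measured step bears on this change in a readable way; the only data available are three limits. Compound 4 is therefore expected to stay near the limit, with a step that the limit leaves unreadable from compound 1 to compound 4 expected to be small or unreadable. The estimate for compound 4 in this assay is 50000 nM, within 15000 nM to 200000 nM.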

Compound 4, half-maximal inhibitory concentration: 2050 nM
For compound 4 the middle estimate is 24-fold (1.39 log units) above the measured one, outside the stated range (below it).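

In this assay the group on the carbon with a double bond to nitrogen can move a compound off the limit, as 4-bromo-2-hydroxyphenyl shows: an at least 19-fold lower number from compound 1 to compound 4 (1.29 log units; beyond the scatter) and an at least 19-fold lower number from compound 2 to compound 4 (1.29 log units; beyond the scatter) and an at least 19-fold lower number from compound 3 to compound 4 (1.29 log units; beyond the scatter). Compound 1, compound 2 and compound 3 each stand at a limit, so these steps give minimum sizes and the steps among those three cannot be read: the limit of >= 40000 nM in this assay, at which 3 of the 4 values shown sit.

Compound 4 brings in bromo and hydroxy together, leaving open which of them carries the step. Also open, from the compounds shown here alone, is whether an amine in place of the hydroxy would keep it.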